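Methyl to 2-fluorobenzyl on the pyridinone nitrogen series

The compounds below may be only part of what the source reports. "The series", "measured", "known", "first", "only" and "open" are said of these compounds alone.

Measured so far:
compound 1 `NC(=O)c1ccccc1Cn1cc(-c2ccc3cn[nH]c3c2)ccc1=O` — 878 nM
compound 2 `Cn1cc(-c2ccc3cn[nH]c3c2)ccc1=O` — > 2000 nM

Within the data shown here, compound 1 is the only member with a numerical reading in an assay for inhibition of MAP kinase-interacting serine/threonine-protein kinase 1 (Homo sapiens), read by luminescence and ADP-Glo, with a stated time of 2 h (a higher number here means a weaker inhibitor, a lower number a stronger inhibitor), where compound 1 gives 878 nM. For compound 2 this assay reports only a limit, > 2000 nM, so compound 2 stands at the limit of > 2000 nM in this assay, at which 1 of the 2 values shown sits, and no number is known for it. The two compounds differ in the group carried on the saturated chain carbon bound to the aromatic nitrogen, compound 2 carrying the smaller one.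

Compound 3 `O=c1ccc(-c2ccc3cn[nH]c3c2)cn1Cc1ccccc1F` is not yet measured. It differs from compound 2 by 2-fluorophenyl in place of hydrogen on a saturated chain carbon bound to an aromatic nitrogen, which, cut one bond further out, reads methyl to 2-fluorobenzyl. Among the measured compounds shown here, no measured step covers this change, so the size of the expected step rests on the comparison above: compound 1, with a larger group on that carbon than compound 2, gives a numerical value where compound 2 gives only a limit.

For compound 3 a value around 1500 nM is expected, a step of an at least 1.3-fold lower number from compound 2 to compound 3 (0.12 log units; that floor lies within the scatter) toward stronger inhibition, with a plausible range from 400 nM to 5000 nM. A limit instead of a number remains possible.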

Compound 3, half-maximal inhibitory concentration: 47 nM
The estimate for compound 3 lay 32-fold (1.50 log units) above the measured number; measured number outside the range, below it.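

In this assay, the saturated chain carbon bound to an aromatic nitrogen proves to be a position where one change moves the reading a long way: 2-fluorophenyl in place of hydrogen gives an at least 42-fold lower number from compound 2 to compound 3 (1.62 log units; beyond the scatter). Compound 2 has only a limit and no number, so this step has a floor but no full size: the limit of > 2000 nM in this assay, at which 1 of the 3 values shown sits. The group on the aromatic carbon also matters, not just the presence of the added ring, since fluoro in place of carbamoyl gives a 19-fold lower number from compound 1 to compound 3 (1.27 log units; beyond the scatter), a large step between two compounds that both carry that ring.

The share of the fluoro and the share of the phenyl ring in this gain remain unresolved, and a plain benzyl group would be needed to separate them. Also open, on these data alone, is how a chloro, a methoxy or an amine on that ring, or a longer chain leading to it, would read in this assay.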